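The source may hold more compounds than are shown below. What is called first, only, known or untested is meant among the compounds shown, and "the series" means these compounds.

Within the data shown here, in an ADME assay on MDCKII-LE cells (Canis lupus familiaris) for permeability (a lower number here means that the compound crosses the layer more slowly, a higher number that the compound crosses the layer faster), compound 2 (`C[C@]1(C#N)C[C@H](CN([C@H](CCC(F)(F)F)C(N)=O)S(=O)(=O)c2ccc(Cl)cc2)C1`) gives 21.8 10^-6 cm/s and compound 1 (`N#CC12CC(CN([C@H](CCC(F)(F)F)C(N)=O)S(=O)(=O)c3ccc(Cl)cc3)(C1)C2`) gives 30.2 10^-6 cm/s, the two being joined by a 1.4-fold lower number from compound 1 to compound 2 (0.14 log units; within the scatter) as the only measured step. Compound 3 (`N#C[C@H]1CC[C@H](CN([C@H](CCC(F)(F)F)C(N)=O)S(=O)(=O)c2ccc(Cl)cc2)CC1`) gives 15.7 10^-6 cm/s; 14.6 10^-6 cm/s (2 entries) in repeat measurements, seen in the several entries of compound 3 in this assay, 15.7 10^-6 cm/s; 14.6 10^-6 cm/s (2 entries) as close agreement. Compound 4 (`NC(=O)[C@@H](CCC(F)(F)F)N(C[C@H]1C[C@@H](c2ncon2)C1)S(=O)(=O)c1ccc(Cl)cc1`) has 3-(1,2,4-oxadiazol-3-yl)cyclobutyl in place of 3-cyano-3-methylcyclobutyl on a saturated chain carbon bound to a sulfonamide nitrogen. Among the measured compounds shown here, no measured step covers this exchange; the nearest guide, compound 2 against compound 1 with a 1.4-fold lower number from compound 1 to compound 2 (0.14 log units; within the scatter), stayed within the scatter. The expected change is a 1.2-fold lower number from compound 2 to compound 4 (0.08 log units; within the scatter), so no shift beyond the scatter is expected. Compound 4 is estimated at 18 10^-6 cm/s, with an expected range of 9 10^-6 cm/s to 32 10^-6 cm/s.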

Compound 4, apparent permeability: 14.1 10^-6 cm/s
Compound 4: middle estimate off by 1.3-fold (0.11 log units), on the high side, and the stated range covers the measured number.
By their numbers in this assay, from the lowest: compounds 4, 2 and 1 (each within the scatter of the next, the first and the last beyond it).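

In this assay, the place on a saturated chain carbon bound to a sulfonamide nitrogen accepts 3-(1,2,4-oxadiazol-3-yl)cyclobutyl with a 1.5-fold lower number from compound 2 to compound 4 (0.19 log units; within the scatter), so a five-membered aromatic ring can replace the nitrile and methyl pair without a shift beyond the scatter. Among these compounds, the wider comparison gives a 2.1-fold lower number from compound 1 to compound 4 (0.33 log units; beyond the scatter), the first step in this set beyond the scatter, and a modest one. Repeat entries in the series agree closely: the several entries of compound 3 in this assay, 15.7 10^-6 cm/s; 14.6 10^-6 cm/s (2 entries)

From the compounds shown here alone, the response of this place to a carboxylic acid or a primary amine on the cyclobutyl remains open. The compounds shown also do not separate the effect of the oxadiazole from that of the lost nitrile.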